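Methyl for chloro in a potent growth-inhibitor pair

This account rests on a few compounds, and the source may have more. Where it says the series, first, only, none or still open, it means among the compounds named here.

In a functional assay on MDA-MB-435 cells (Homo sapiens) for antiproliferative activity (a higher number here means a weaker inhibitor of growth, a lower number a stronger inhibitor of growth), compound 1 `Cc1ccnc2nc(-c3cccc(Cl)c3)cc(O)c12` gives < 10 nM, which is a limit of the assay and not a number. Compound 2 `Cc1ccc2c(O)cc(-c3cccc(Cl)c3)nc2n1` gives < 10 nM, likewise a limit. Compound 2 therefore stands with compound 1 at the same limit, as the limit of < 10 nM in this assay, at which 2 of the 2 values shown sit, shows, and neither has an exact number.

Compound 3 `Cc1cccc(-c2cc(O)c3ccc(C)nc3n2)c1` shares the core of compound 2 but has methyl in place of chloro on an aromatic carbon, on a six-membered aromatic ring of carbon only, meta to a large group (methyl in place of chloro on an aromatic carbon). Going by the values given here, no measured step between related compounds shows what this exchange does in this assay. A small change toward weaker growth inhibition is expected, possibly none beyond the scatter, and the reading may again be a limit. The expected change is an at least 1.2-fold higher number from compound 2 to compound 3 (0.07 log units; that floor lies within the scatter), and this remains only an estimate. For compound 3 the estimated value is 12 nM, with an expected range from 4 nM to 60 nM.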

Compound 3, concentration for 50% growth inhibition: 32.4 nM
Estimate against measurement, compound 3: 2.7-fold (0.43 log units) below, and the stated range covers the measured number.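

Going by these compounds alone, compound 3 is the only one of the three compounds with an exact number in this assay, so it gives the first measured reading that is not a limit. Methyl in place of chloro on an aromatic carbon, meta to a large group, gives an at least 3.2-fold higher number from compound 2 to compound 3 (0.51 log units; beyond the scatter), which shows that this position responds to the exchange and that the chloro compound is the stronger inhibitor of growth of this pair. The step can be read only as a lower bound on the true difference, because compound 2 is held at a limit of the assay and not at a number: the limit of < 10 nM in this assay, at which 2 of the 3 values shown sit.

The compounds shown leave open how the same aromatic carbon would read with a different group, such as methoxy, an amine or a carboxylic acid, and so whether chloro is unusual there or methyl is. They also leave open the exact size of the step, and whether the same exchange would have a comparable effect on the core of compound 1.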